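This account rests on a few compounds, and the source may have more. Where it says the series, first, only, none or still open, it means among the compounds named here.

Measured compounds:
compound 1, `CC(C)(C)C(=O)OCC1(CO)C/C(=C\CCCCCCCCCCCO)C(=O)O1`, 2.49 ug/mL
compound 2, `COCCCCCCCCCCCCCCC/C=C1\CC(CO)(COC(=O)C(C)(C)C)OC1=O`, 0.118 ug/mL
compound 3, `CC(C)(C)C(=O)OCC1(CO)C/C(=C/CCCCCCCCCCCCCCC=O)C(=O)O1`, 5.14 ug/mL

All three share one core and were tested in a functional assay on COLO 205 cells (Homo sapiens) for antiproliferative activity; a lower number here means a stronger inhibitor of growth, a higher number a weaker inhibitor of growth. Going by the values given here, compound 2 gives the lowest number of the three; compound 1 gives a number a 21-fold lower number from compound 1 to compound 2 (1.32 log units; beyond the scatter) away in the weaker direction, and compound 3, with no single-point step to compound 2, sits further still. Among the compounds with values here, the one measured step, a 21-fold lower number from compound 1 to compound 2 (1.32 log units; beyond the scatter), is large and beyond the scatter, and it changes a hydroxy far along the chain to a 4-methoxybutyl, so it lengthens and caps the chain at once.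

The new compound, compound 4, `CCCCCOCCCCCCC/C=C1\CC(CO)(COC(=O)C(C)(C)C)OC1=O`, differs from compound 2 in this way: pentyloxy in place of 8-methoxyoctyl on a saturated chain carbon, seven bonds along the chain from a double-bonded chain carbon. The chain of compound 4 is therefore shorter overall and carries its ether nearer to the core. Within the data shown here, no measured step isolates chain length or ether position; the only step that touches the chain end, a 21-fold lower number from compound 1 to compound 2 (1.32 log units; beyond the scatter), rewards a longer capped chain. The step from compound 2 to compound 4 runs the other way in length, so a move back toward weaker growth inhibition is expected, of moderate size, a 4.2-fold higher number from compound 2 to compound 4 (0.63 log units; beyond the scatter). Compound 4 is estimated at 0.5 ug/mL, in the range 0.15 ug/mL to 2 ug/mL.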

Compound 4, concentration for 50% growth inhibition: 0.491 ug/mL
Compound 4: middle estimate off by 1.0-fold (0.01 log units), on the high side; low and high end bracket the measured number.
By their numbers in this assay, from the lowest: compound 2; then compound 4; then compound 1; then compound 3.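

In this assay, the change of 8-methoxyoctyl to pentyloxy, seven bonds along the chain from a double-bonded chain carbon, gives a 4.2-fold higher number from compound 2 to compound 4 (0.62 log units; beyond the scatter), so shortening the capped chain and bringing its ether oxygen to this position costs some growth inhibition but does not remove it. Going by these compounds alone, replacing 4-hydroxybutyl with pentyloxy at the same place gives a 5.1-fold lower number from compound 1 to compound 4 (0.71 log units; beyond the scatter), which shows that part of the gain seen earlier does not need a chain as long as the one in compound 2, and that a chain ending in a plain pentyl group can outperform one ending in hydroxy. Nothing in the data shown accounts for either difference.

Chain length and ether position still change together in these steps, so the share of each in the loss of growth inhibition remains unresolved. As far as these compounds go, it also remains open whether the ether oxygen matters at all, which an unbroken all-carbon chain of the same length would test, and how a terminal amine or carboxylic acid would behave at the chain end.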